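Swapping the Pyridine on the Amine Nitrogen

The compounds below may be only part of what the source reports. "The series", "measured", "known", "first", "only" and "open" are said of these compounds alone.

Compound 1, `Cc1ccc(-n2nccn2)c(C(=O)N2CC3(CC3)C[C@H]2CNc2ccc(Cl)cn2)c1`: < 5
Compound 2, `Cc1ccc(-c2ncccn2)c(C(=O)N2CC3(CC3)C[C@H]2CNc2ccc(Cl)cn2)c1`: < 5

In a functional assay on HEK293 cells for antagonist activity at Orexin receptor type 2 (Homo sapiens), read by FLIPR and calcium flux (a lower number here means a less potent compound, a higher number a more potent compound, by a factor of ten per unit of this negative logarithm), compound 1 gives < 5, which is a limit of the assay rather than a number. Compound 2 likewise gives < 5, also a limit. The step that the two limits leave unreadable from compound 1 to compound 2 therefore cannot be sized; both values sit at the limit of < 5 in this assay, at which 2 of the 2 values shown sit. Compound 3, `Cc1ccc(-n2nccn2)c(C(=O)N2CC3(CC3)C[C@H]2CNc2cccc(C)n2)c1`, differs from compound 1 by 6-methylpyridin-2-yl in place of 5-chloropyridin-2-yl on an amine nitrogen. For the measured compounds named here, no measured step touches this change, and compound 1 itself offers only a limit as anchor. Compound 3 is thus expected to stay near that limit, estimated at 5 within 4.3 to 5.7, a step of a number no lower from compound 1 to compound 3 (the limit leaves the size open).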

Compound 3, negative logarithm of the antagonist equilibrium constant: < 5
Compound 3: only a limit was reported; the forecaster's own chance of this, stated with the estimate: 60%; the middle value sits exactly at the limit.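

Compound 3 gives < 5 as a limit of the assay, not a number. For the compounds shown here, compound 1 also stands at a limit, so no step between compound 1 and compound 3 can be read. Going by these compounds, how 6-methylpyridin-2-yl and 5-chloropyridin-2-yl compare on the amine nitrogen stays open.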